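One Change on Two Cores: What to Expect of Compound 4

This account rests on a few compounds, and the source may have more. Where it says the series, first, only, none or still open, it means among the compounds named here.

Compound 1 `O=[N+]([O-])c1cccc(NC(=S)NCCNS(=O)(=O)c2ccc(-c3ccccc3OCc3ccccc3)s2)c1`: > 50000 nM
Compound 2 `O=C(NCCNS(=O)(=O)c1ccc(-c2ccccc2OCc2ccccc2)s1)Nc1cccc([N+](=O)[O-])c1`: 2800 nM
Compound 3 `Cc1ccc(-c2ccsc2S(=O)(=O)NCCNC(=S)Nc2cccc([N+](=O)[O-])c2)c(Oc2ccc(O)c(O)c2)c1`: 3400 nM

In a functional assay on HL-60 cells (Homo sapiens) for inhibition, read by CCK-8 assay, with a stated time of 48 h (a lower number here means a stronger inhibitor, a higher number a weaker inhibitor), compound 1 sits at a limit of the assay, not at a number (the limit of > 50000 nM in this assay, at which 1 of the 3 values shown sits). Compound 2 gives 2800 nM in this assay. The change between them, (a group of 12 heavy atoms (7 carbon, 2 nitrogen, 3 oxygen; one six-membered aromatic ring of carbon only) in place of a group of 12 heavy atoms (7 carbon, 2 nitrogen, 2 oxygen, 1 sulfur; one six-membered aromatic ring of carbon only), on an amine nitrogen), produced an at least 17-fold lower number from compound 1 to compound 2 (1.25 log units; beyond the scatter). Compound 3 gives 3400 nM in this assay. Compound 4 `Cc1ccc(-c2ccsc2S(=O)(=O)NCCNC(=O)Nc2cccc([N+](=O)[O-])c2)c(Oc2ccc(O)c(O)c2)c1` differs from compound 3 by the same change, (a group of 12 heavy atoms (7 carbon, 2 nitrogen, 3 oxygen; one six-membered aromatic ring of carbon only) in place of a group of 12 heavy atoms (7 carbon, 2 nitrogen, 2 oxygen, 1 sulfur; one six-membered aromatic ring of carbon only), on an amine nitrogen), at a place described in identical words. How the core of compound 1 and the core of compound 3 differ is not broken down here. Compound 4 is expected to show a 3.4-fold lower number from compound 3 to compound 4 (0.53 log units; beyond the scatter) in this assay, a smaller step than the earlier one, because an at least 17-fold lower number from compound 1 to compound 2 (1.25 log units; beyond the scatter) starts from a limit whereas compound 3 starts from a measured number. The estimate for compound 4 in this assay is 1000 nM, expected to lie between 250 nM and 4000 nM.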

Compound 4, half-maximal inhibitory concentration: 6000 nM
Estimate against measurement, compound 4: 6.0-fold (0.78 log units) below; the whole stated range lies below it.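

Placed on the second core, the (3-nitrophenyl)carbamoyl group produced a 1.8-fold higher number from compound 3 to compound 4 (0.25 log units; within the scatter) in this assay, and the two steps do not agree: the same change on two cores in this assay, an at least 17-fold lower number (1.25 log units; beyond the scatter) from compound 1 to compound 2 and a 1.8-fold higher number (0.25 log units; within the scatter) from compound 3 to compound 4, at least 31-fold (1.49 log units) apart, beyond the scatter of two such steps Compound 1 stands at > 50000 nM, which is a limit of the assay and not a number. In these two pairs the result of the change therefore depends on the core, but the pairs do not show which difference between the cores matters, and they set no rule for the wider series.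

The compounds shown leave open how the change behaves on any further core. They also leave open whether a carboxylic acid or an amine in place of the (3-nitrophenyl)carbamoyl group, or a longer chain on the amine nitrogen, would alter the outcome.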